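Compound 1 to compound 4: methoxy replaces chloro

This account rests on a few compounds, and the source may have more. Where it says the series, first, only, none or still open, it means among the compounds named here.

Compound 1, `CNC(=O)c1cc(Oc2ccc(NC(=O)c3cc(-c4ccc(Cl)cc4)ncn3)cc2F)ccn1`, was tested in a functional assay on A549 cells (Homo sapiens) for cytotoxicity, read by MTT assay, with a stated time of 72 h; on this read-out higher numbers stand for weaker inhibition and lower numbers for stronger inhibition. Compound 1 reads > 100000 nM, which is a limit of the assay and not a number, so its position can be given only as a bound. Compound 2, `CNC(=O)c1cc(Oc2ccc(NC(=O)c3cc(-c4ccc(C)cc4)ncn3)cc2)ccn1`, reads > 100000 nM, and this too is a limit. Going by the values given here, compound 3, `CNC(=O)c1cc(Oc2ccc(NC(=O)c3nccc(-c4ccc(C)cc4)n3)cc2)ccn1`, gives 28400 nM, the only true number so far. The three compounds together show (the limit of > 100000 nM in this assay, at which 2 of the 3 values shown sit).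

Compound 4, `CNC(=O)c1cc(Oc2ccc(NC(=O)c3cc(-c4ccc(OC)cc4)ncn3)cc2F)ccn1`, keeps the core of compound 1 and carries methoxy in place of chloro on an aromatic carbon, the change from 4-chlorophenyl to 4-methoxyphenyl: methoxy in place of chloro on an aromatic carbon. The swap sits para to a large group. Among the compounds with values here, no measured pair of compounds isolates this change, so its size cannot be read from the data. In this assay, the expectation is therefore a small step towards stronger inhibition at most, and quite possibly none beyond the scatter. The limit reading of compound 1 at > 100000 nM is the basis for that expectation, and compound 4 may well end at the same limit. The expected step is an at least 1.6-fold lower number from compound 1 to compound 4 (0.22 log units; that floor lies within the scatter). For compound 4 the estimated value is 60000 nM, with an expected range from 20000 nM to 100000 nM.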

Compound 4, half-maximal inhibitory concentration: 34500 nM
Compound 4: middle estimate off by 1.7-fold (0.24 log units), on the high side; measured number inside the range.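

In this assay, methoxy in place of chloro on an aromatic carbon gives an at least 2.8-fold lower number from compound 1 to compound 4 (0.46 log units; beyond the scatter), so this position, para to a large group, is one where a single change can bring a compound off the limit and onto a true number. Compound 1 reads > 100000 nM, which is a limit and not a number, so the step has a lower bound but no known full size. Going by these compounds alone, compound 4 is the first compound on the core of compound 1 to give a true number, although limit readings still stand among the values shown: the limit of > 100000 nM in this assay, at which 2 of the 4 values shown sit.

From the compounds shown here alone, whether the step belongs to methoxy itself or would follow from other replacements of chloro stays open, and so does whether an amine, a hydroxyl or a longer chain such as ethoxy at this position would give a lower number than compound 4 does. The compounds shown also give no cause for the step, and they cannot tell whether the same swap would have a similar effect on another core.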